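Methoxy removal on a diarylpropane core, estimated from a chalcone pair

The source may report more compounds than this note shows. Statements on the series, on what has been measured and on what is new or still open speak of the compounds shown alone.

Compound 1 `COc1ccc(CCCc2ccc(OC)cc2OC)c(O)c1` gives 25.8% in an ADME assay on RAW264.7 cells (Mus musculus) for cytotoxicity, read by MTT assay, with a stated time of 24 h, tested at 10 ug/mL (on this read-out higher numbers stand for a weaker effect at the one concentration tested and lower numbers for a stronger effect), the lowest of the three numbers. Compound 2 `COc1ccc(/C=C/C(=O)c2ccc(OC)c(OC)c2)cc1` gives 73.9% in this assay, and compound 3 `COc1ccc(/C=C/C(=O)c2ccc(OC)c(OC)c2)cc1OC` gives 60.4%. Compound 2 and compound 3 differ by hydrogen in place of methoxy on an aromatic carbon, and a number 13.5 percentage points higher from compound 3 to compound 2 (beyond the scatter). The same kind of change leads from compound 1 to compound 4 `COc1ccc(CCCc2ccc(OC)cc2O)cc1`, namely (hydrogen in place of methoxy on an aromatic carbon); here the carbon is ortho to a large group and meta to a methoxy group, whereas in the measured pair it is ortho to a methoxy group and meta to a large group. The difference between the core of compound 1 and the core of compound 3 is not broken down here. For compound 4 a step of about a number 14.2 percentage points higher from compound 1 to compound 4 (beyond the scatter) is expected in this assay, beside the measured one, because a number 13.5 percentage points higher from compound 3 to compound 2 (beyond the scatter) came from the same kind of change, with wide bounds since the cores differ. Compound 4 is therefore estimated at 40% in this assay, between 22% and 62%.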

Compound 4, a percentage reported as activity, at one concentration (the size of the read-out at that concentration, not a potency): 73.8%
Compound 4: the middle estimate sits 33.8 percentage points below what was measured; the whole stated range lies below it.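

In this assay, hydrogen in place of methoxy on the core of compound 1 gives a number 48 percentage points higher from compound 1 to compound 4 (beyond the scatter), so a step measured on one core in this series does not give a reliable size for the same change on the other. The two steps run in the same direction, towards a weaker effect at the one concentration tested, but they differ in size: the same change on two cores in this assay, a number 13.5 percentage points higher (beyond the scatter) from compound 3 to compound 2 and a number 48 percentage points higher (beyond the scatter) from compound 1 to compound 4, 34.5 percentage points apart, beyond the scatter of two such steps

This does not show what sets the size, since the two pairs differ in their core and in the place of the change, which in compound 4 is on a carbon ortho to a large group and meta to a methoxy group, and one pair per core cannot separate these. The compounds shown leave open whether removing either of the other methoxy groups of compound 1 would give a step of similar size. They also leave open what an amine or a fluorine in place of the methoxy group lost in compound 4 would give on this core.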